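Swapping the aryl group on the shared core: compound 3

The source may hold more compounds than are shown below. What is called first, only, known or untested is meant among the compounds shown, and "the series" means these compounds.

Measured compounds in a functional assay on A549 cells (Homo sapiens) for antiproliferative activity, read by MTT assay, with a stated time of 72 h; on this read-out higher numbers stand for weaker inhibition and lower numbers for stronger inhibition:
compound 1, `NS(=O)(=O)c1ccc(NC(=S)Nc2ccc3ncnc(Nc4cccc(Br)c4)c3c2)cc1`, 25000 nM
compound 2, `NS(=O)(=O)c1ccc(NC(=S)Nc2ccc3ncnc(Nc4cccc(F)c4)c3c2)cc1`, 25900 nM

Compound 2 stands alongside compound 1 in this assay: the step of a 1.0-fold higher number from compound 1 to compound 2 (0.02 log units; within the scatter) keeps both at the same weak level, so neither can be set apart from the other.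

Compound 3, `Cc1ccc(Nc2ncnc3ccc(NC(=S)Nc4ccc(S(N)(=O)=O)cc4)cc23)cc1`, carries the change (4-methylphenyl in place of 3-fluorophenyl on a nitrogen on an aromatic ring). In words, the 3-fluorophenyl group attached to the nitrogen on the aromatic ring is replaced by 4-methylphenyl, a ring of the same size without the fluorine.

Among the compounds with values here, only one measured step exists, and it concerns a different swap, bromo for fluoro on the same aryl ring; it was a 1.0-fold higher number from compound 1 to compound 2 (0.02 log units; within the scatter), that is, nothing beyond the scatter. Within the data shown here, no measured pair shows what a methyl group does here, nor what happens when the substituent moves to a different position of that ring. Among the measured compounds shown here, with the two measured compounds sitting at one level and the single step flat, compound 3 is expected to stay near that level as well, with the step of a 1.0-fold lower number from compound 2 to compound 3 (0.02 log units; within the scatter) estimated to fall within the scatter. The estimate for compound 3 is 25000 nM, between 9000 nM and 70000 nM.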

Compound 3, half-maximal inhibitory concentration: 2840 nM
Estimate against measurement, compound 3: 8.8-fold (0.94 log units) above; measured number below the stated range.
By their numbers in this assay, from the lowest: compound 3; then compounds 1 and 2 (each within the scatter of the next).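

In this assay the aryl group on a nitrogen on an aromatic ring clearly matters: 4-methylphenyl in place of 3-fluorophenyl gives a 9.1-fold lower number from compound 2 to compound 3 (0.96 log units; beyond the scatter) and 4-methylphenyl in place of 3-bromophenyl gives an 8.8-fold lower number from compound 1 to compound 3 (0.94 log units; beyond the scatter), both beyond the scatter. The earlier swap of bromo for fluoro gave only a 1.0-fold higher number from compound 1 to compound 2 (0.02 log units; within the scatter), so that flat result described one narrow change and not the position as a whole. No measurement available here explains why the 4-methylphenyl compound gives the lower number.

The change from 3-fluorophenyl to 4-methylphenyl alters both the substituent and its location on the ring, so these three compounds cannot show whether the methyl group, its location or the two together account for the step. A 3-methylphenyl or 4-fluorophenyl group on the same nitrogen would help to separate those two parts of the change, while an ethyl or methoxy group in place of the methyl would show whether the lower number persists with a different substituent at that location.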